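Dropping the Methoxy from an Indole Vinyl Sulfone

The source may hold more compounds than are shown below. What is called first, only, known or untested is meant among the compounds shown, and "the series" means these compounds.

Compound 2, `COc1ccc(-c2[nH]c3ccccc3c2/C=C(\C#N)S(=O)(=O)c2ccccc2)cc1`: 997 nM
Compound 1, `CC(=O)/C(=C\c1c(-c2ccccc2)[nH]c2ccccc12)S(=O)(=O)c1ccccc1`: 2400 nM

In a functional assay on CAKI-1 cells (Homo sapiens) for inhibition, read by sulforhodamine B assay, with a stated time of 48 h (a lower number here means a stronger inhibitor of growth, a higher number a weaker inhibitor of growth), compound 2 gives 997 nM, the lower of the two numbers; compound 1 gives 2400 nM, a higher number beyond the scatter. Compound 3, `N#C/C(=C\c1c(-c2ccccc2)[nH]c2ccccc12)S(=O)(=O)c1ccccc1`, differs from compound 2 by hydrogen in place of methoxy on an aromatic carbon. Within the data shown here, no pair of measured compounds shows this change, so its size is untested here. The expectation is a modest step, probably toward a higher number, within or just beyond the scatter: a 1.5-fold higher number from compound 2 to compound 3 (0.18 log units; within the scatter). Compound 3 is therefore estimated at 1500 nM, ranging from 500 nM to 4500 nM.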

Compound 3, concentration for 50% growth inhibition: 5500 nM
The estimate for compound 3 lay 3.7-fold (0.56 log units) below the measured number; measured number outside the range, above it.
By their numbers in this assay, from the lowest: compound 2; then compound 1; then compound 3.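

In this assay the change from 4-methoxyphenyl to phenyl brings a 5.5-fold higher number from compound 2 to compound 3 (0.74 log units; beyond the scatter) and so shows that this position is not indifferent to what it carries. With phenyl in place, cyano in place of acetyl on the double-bonded chain carbon brings a 2.3-fold higher number from compound 1 to compound 3 (0.36 log units; beyond the scatter) and leaves the acetyl compound 1 the stronger inhibitor of this pair. Nothing measured here accounts for either step. Going by these compounds, whether an amine, a hydroxyl or a longer alkoxy chain at this position would match methoxy remains open, as does whether acetyl paired with 4-methoxyphenyl would add to the effect.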